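The compounds below may be only part of what the source reports. "The series", "measured", "known", "first", "only" and "open" are said of these compounds alone.

Among the compounds with values here, in a physicochemical assay for solubility, read by HPLC, with a stated time of 4 h, at pH 7 (on this read-out lower numbers stand for lower solubility and higher numbers for higher solubility), compound 1 `C[C@]1(COc2ccc(N3CCN(S(=O)(=O)c4ccc(F)cc4)CC3)cc2)Cn2cc([N+](=O)[O-])nc2O1` gives 8.33 ug/mL, the only true number available so far. Compound 2 `C[C@]1(COc2ccc(-n3cc(COc4ccc(OC(F)(F)F)cc4)nn3)cc2)Cn2cc([N+](=O)[O-])nc2O1` reads < 1 ug/mL, which is a limit of the assay and not a number. Compound 3 `COc1ccc(S(=O)(=O)N2CCN(c3ccc(OC[C@@]4(C)Cn5cc([N+](=O)[O-])nc5O4)cc3)CC2)cc1` carries methoxy in place of fluoro on an aromatic carbon, para to a large group: methoxy in place of fluoro on an aromatic carbon. Within the data shown here, no measured pair shows this change, so the expected step of a 1.2-fold lower number from compound 1 to compound 3 (0.08 log units; within the scatter) is one within the scatter, with neither direction favoured. For compound 3 the estimated value in this assay is 7 ug/mL, with an expected range of 3 ug/mL to 16 ug/mL.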

Compound 3, solubility: < 1 ug/mL
Compound 3 was reported as a limit (the forecaster's own chance of this, stated with the estimate: 5%); middle value at least 7.0-fold (0.84 log units) from the limit.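

In this assay compound 3 reads < 1 ug/mL, which is a limit of the assay and not a number. Methoxy in place of fluoro on an aromatic carbon, para to a large group, gives an at least 8.3-fold lower number from compound 1 to compound 3 (0.92 log units; beyond the scatter), the first measured step at this position, and it shows that this small change is not neutral here. The step is printed only as a bound, and the limit behind it recurs in this set: the limit of < 1 ug/mL in this assay, at which 2 of the 3 values shown sit.

The compounds shown leave open whether this step belongs to methoxy alone or would also follow from another group at this position. A hydrogen, chloro or an amine in that place remains untested in what is shown here.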